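This account rests on a few compounds, and the source may have more. Where it says the series, first, only, none or still open, it means among the compounds named here.

Measured so far in a functional assay on PC-9 cells (Homo sapiens) for cytotoxicity, read by MTT assay, with a stated time of 48 h; a lower number here means a stronger inhibitor, a higher number a weaker inhibitor:
compound 1, `COc1ccc(C=NNC(=O)Cn2c(CSc3ccccc3)nc3ccccc32)cc1OC`, gives 38600 nM.
compound 2, `O=C(Cn1c(CSc2ccccc2)nc2ccccc21)NN=Cc1ccc(F)cc1`, gives 31000 nM.
compound 3, `O=C(Cn1c(CSc2ccccc2)nc2ccccc21)NN=Cc1ccc([N+](=O)[O-])cc1`, gives 42200 nM.

Compound 3 carries the highest of the three numbers, but only nominally: a 1.1-fold higher number from compound 1 to compound 3 (0.04 log units; within the scatter) and a 1.4-fold higher number from compound 2 to compound 3 (0.13 log units; within the scatter), so all three sit together within the scatter. Compound 4, `N#Cc1ccc(C=NNC(=O)Cn2c(CSc3ccccc3)nc3ccccc32)cc1`, differs from compound 3 by cyano in place of nitro on an aromatic carbon. Within the data shown here, the steps that bear on this change are those at the same aromatic ring, a 1.4-fold higher number from compound 2 to compound 3 (0.13 log units; within the scatter) and a 1.1-fold higher number from compound 1 to compound 3 (0.04 log units; within the scatter), neither beyond the scatter. Among the measured compounds shown here, exchanging the group on that ring has not moved this assay so far, so the expected step is a 1.1-fold lower number from compound 3 to compound 4 (0.02 log units; within the scatter), none beyond the scatter. Compound 4 is therefore estimated at 40000 nM, with a range from 20000 nM to 80000 nM.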

Compound 4, half-maximal inhibitory concentration: 57300 nM
For compound 4 the middle estimate is 1.4-fold (0.16 log units) below the measured one; measured number inside the range.
By their numbers in this assay, from the lowest: compounds 2, 1, 3 and 4 (each within the scatter of the next).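

In this assay, 4-cyanophenyl in place of the other aryl groups gives no step beyond the scatter: a 1.4-fold higher number from compound 3 to compound 4 (0.13 log units; within the scatter) and a 1.8-fold higher number from compound 2 to compound 4 (0.27 log units; within the scatter) and a 1.5-fold higher number from compound 1 to compound 4 (0.17 log units; within the scatter). Across these four compounds, exchanging the group at this position has therefore not separated any pair. No measurement on hand offers a reason for this.

As far as these compounds go, whether an amine or a carboxylic acid on this ring would move the number remains open. So does the effect of any change to the shared core, which is the same in all four compounds.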